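Working notes: from compound 3 to compound 4

The source may hold more compounds than are shown below. What is called first, only, known or untested is meant among the compounds shown, and "the series" means these compounds.

Measured in a functional assay on the whole organism (strain Swiss albino) with Mus musculus as the target, with a stated time of 0.5 h; on this read-out lower numbers stand for an effect already at smaller amounts and higher numbers for an effect only at larger amounts of compound:
- compound 1, `O=C(N/N=C/c1ccc(Cl)cc1Cl)Nc1cccc2ccccc12`: 300 mg/kg
- compound 2, `O=C(N/N=C/c1ccc(F)cc1)Nc1cccc2ccccc12`: 300 mg/kg
- compound 3, `COc1cccc(/C=N/NC(=O)Nc2cccc3ccccc23)c1`: 100 mg/kg

Compound 3 stands lowest of the three numbers. Both steps toward it go beyond the scatter: a 3.0-fold lower number from compound 1 to compound 3 (0.48 log units; beyond the scatter) and a 3.0-fold lower number from compound 2 to compound 3 (0.48 log units; beyond the scatter). Between the two halogen-bearing compounds there is nothing to separate: no change at the digits printed from compound 1 to compound 2 (within the scatter).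

Compound 4, `O=C(N/N=C/c1ccc(Br)cc1)Nc1cccc2ccccc12`, is the next member. Its difference from compound 3 is 4-bromophenyl in place of 3-methoxyphenyl on a carbon with a double bond to nitrogen. The relevant comparisons are the two steps into compound 3, each of which exchanged a halogen-bearing phenyl for the 3-methoxyphenyl and lowered the number by a modest amount. Compound 4 runs that exchange backwards, putting a halogen-bearing phenyl in again. The expectation is therefore a modest step toward a higher number, of about the size seen in those two steps, so that compound 4 comes to rest near compounds 1 and 2: the expected step is a 3.0-fold higher number from compound 3 to compound 4 (0.48 log units; beyond the scatter). Compound 4 is estimated at 300 mg/kg, within a range of 100 mg/kg to 600 mg/kg.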

Compound 4, minimum effective dose: 300 mg/kg
For compound 4 middle estimate and measured number coincide at the digits printed, within the range that was stated.
By their numbers in this assay, from the lowest: compound 3; then compounds 1, 2 and 4 (each within the scatter of the next).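

In this assay, putting 4-bromophenyl in place of 3-methoxyphenyl on the carbon with a double bond to nitrogen gives a 3.0-fold higher number from compound 3 to compound 4 (0.48 log units; beyond the scatter), so the earlier gain is lost with a third halogen-bearing phenyl. Bromo in place of fluoro gives no change at the digits printed from compound 2 to compound 4 (within the scatter), and 4-bromophenyl in place of 2,4-dichlorophenyl gives no change at the digits printed from compound 1 to compound 4 (within the scatter), so the three halogen-bearing compounds form one group with compound 3 standing apart, and none of the four goes against this. No available evidence explains this separation.

Among the compounds shown here, compound 3 remains the only member without a halogen, so a single compound carries the lower number. From the compounds shown here alone, whether other groups at this place, such as a phenyl bearing an amine or a carboxylic acid, would match it remains open.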